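Swapping the fluorinated aryl cap of a chromone kinase inhibitor

A few compounds are considered here, and "the series" means these few. Any claim that something is new, unique, unknown or untested is made for them only; others in the source may bear on it.

Measured so far:
compound 1 `Cc1ccc(C(=O)Nc2cccc(NC(=O)COc3ccc4c(=O)ccoc4c3)c2)cc1` gives 183 nM in an assay on isolated protein for inhibition of Rho-associated protein kinase 1 (Homo sapiens), read by scintillation counting, radiometric assay and 33P incorporation, with a stated time of 40 min, in the presence of a further agent that is not named here; on this read-out higher numbers stand for weaker inhibition and lower numbers for stronger inhibition
compound 2 `O=C(COc1ccc2c(=O)ccoc2c1)Nc1cccc(NC(=O)c2ccc(OC(F)(F)F)cc2)c1` gives 869 nM in this assay

Compound 2 stands highest of the two numbers, that is, it is the weaker inhibitor. Within the data shown here, the one step seen is a 4.7-fold higher number from compound 1 to compound 2 (0.68 log units; beyond the scatter). Compound 3 `Cc1cc(C(=O)Nc2cccc(NC(=O)COc3ccc4c(=O)ccoc4c3)c2)ccc1C(F)(F)F` changes compound 2 again at the same end of the molecule: a group of 11 heavy atoms (8 carbon, 3 fluorine; one six-membered aromatic ring of carbon only) in place of a group of 11 heavy atoms (7 carbon, 1 oxygen, 3 fluorine; one six-membered aromatic ring of carbon only), on a carbonyl carbon. The entering group has no common name; it carries three fluorine atoms, as the leaving group did, but no oxygen. Among the measured compounds shown here, no measured step covers this exact change. The step from compound 1 to compound 2 showed that adding fluorine at this end raised the number, and compound 3 keeps fluorine there, so a number nearer compound 2 than compound 1 is expected, with the step of a 1.4-fold lower number from compound 2 to compound 3 (0.16 log units; within the scatter) expected to stay within the scatter. Compound 3 is estimated at 600 nM, between 180 nM and 2000 nM.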

Compound 3, half-maximal inhibitory concentration: 460 nM
Beside the measured number, compound 3's estimate is 1.3-fold (0.12 log units) above it; the measured number falls inside the stated range.
By their numbers in this assay, from the lowest: compound 1; then compounds 3 and 2 (each within the scatter of the next).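

Removing the oxygen from the cap while keeping the three fluorine atoms gives a 1.9-fold lower number from compound 2 to compound 3 (0.28 log units; within the scatter), so in this assay these two caps cannot be told apart. Against the smaller cap of compound 1, the new cap gives a 2.5-fold higher number from compound 1 to compound 3 (0.40 log units; beyond the scatter), which means that both fluorine-bearing caps, in compound 2 and compound 3, now stand beyond the scatter above compound 1, with or without the oxygen of the trifluoromethoxy group. Nothing available explains why the numbers differ at this position.

Still open, as far as these compounds go, is whether the higher numbers follow the three fluorine atoms themselves or the larger cap, since both caps carry the two features together. Also open, from the compounds shown here alone, is how a cap bearing an amine or a carboxylic acid would compare with compound 1.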